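Meta-substituent change on the phenoxy ring of the coumarin series

The source may report more compounds than this note shows. Statements on the series, on what has been measured and on what is new or still open speak of the compounds shown alone.

Measured so far:
compound 1 `Cc1nn(C)c(Oc2cccc(F)c2)c1/C=N\CCCCCOc1cc2oc(=O)cc(C)c2cc1Cl` — 11800 nM
compound 2 `Cc1nn(C)c(Oc2cccc(Cl)c2)c1/C=N\CCCCCCOc1cc2oc(=O)cc(C)c2cc1Cl` — 5260 nM

In a functional assay on SMMC-7721 cells (Homo sapiens) for antiproliferative activity, read by MTT assay, with a stated time of 72 h (a lower number here means a stronger inhibitor, a higher number a weaker inhibitor), compound 2 gives 5260 nM, the lowest of the two numbers; compound 1 gives 11800 nM, and the two differ in more than one place, so only the gap between their values is known. Compound 3 `Cc1nn(C)c(Oc2cccc(C(F)(F)F)c2)c1/C=N\CCCCCCOc1cc2oc(=O)cc(C)c2cc1Cl` carries the change trifluoromethyl in place of chloro on an aromatic carbon relative to compound 2. For the measured compounds named here, no measured pair shows this kind of swap, so the step is expected to stay within the scatter, with no clear direction. The estimated step from compound 2 to compound 3 is a 1.2-fold lower number from compound 2 to compound 3 (0.07 log units; within the scatter). Compound 3 is expected at 4500 nM, within 2000 nM to 11000 nM.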

Compound 3, half-maximal inhibitory concentration: 24800 nM
Compound 3: middle estimate off by 5.5-fold (0.74 log units), on the low side; measured number outside the range, above it.
By their numbers in this assay, from the lowest: compound 2; then compound 1; then compound 3.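

In this assay, going from 3-chlorophenoxy to 3-(trifluoromethyl)phenoxy gives a 4.7-fold higher number from compound 2 to compound 3 (0.67 log units; beyond the scatter). For the compounds shown here, this is the first single-place step, and it shows that the substituent on this aromatic carbon moves the read-out beyond the scatter, with trifluoromethyl the poorer of the two groups here. Nothing at hand accounts for the step.

One step cannot show how a methoxy group, a nitrile or an amine on this carbon would read. Fluoro and chloro also remain unseparated, since compound 1 differs from compound 2 in more than one place.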